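The compounds below may be only part of what the source reports. "The series", "measured", "known", "first", "only" and "open" are said of these compounds alone.

Three compounds share a core that carries a group on an amide-type nitrogen in a ring. Compound 1 `COc1ccc(F)cc1N1C(=O)CSC1c1cccc(C(=O)NCCCCn2cccn2)c1` gives 50000 nM in a physicochemical assay for solubility, read by turbidimetry, measured as kinetic solubility, at pH 6.8; a higher number here means a more soluble compound, a lower number a less soluble compound. Compound 2 `O=C(NCCCCc1ccccc1)c1cccc(C2SCC(=O)N2c2cccc(F)c2)c1` gives 10000 nM, and compound 3 `CC(F)(F)c1cccc(N2C(=O)CSC2c2cccc(C(=O)NCCCCc3ccccc3)c2)c1` gives 10000 nM, level with compound 2 and together the lowest of the three, while compound 1 lies beyond the scatter above both. Within the data shown here, the only measured step that changes this group, no change at the digits printed from compound 2 to compound 3 (within the scatter), shows no change. Compound 4 `COc1ccc(F)cc1N1C(=O)CSC1c1cccc(C(=O)NCCCCc2ccccc2)c1` differs from compound 3 by a group of 9 heavy atoms (7 carbon, 1 oxygen, 1 fluorine; one six-membered aromatic ring of carbon only) in place of a group of 10 heavy atoms (8 carbon, 2 fluorine; one six-membered aromatic ring of carbon only), on an amide-type nitrogen in a ring. Among the measured compounds shown here, the entering group is the one carried by compound 1, whose value is higher, but that pair also differs elsewhere, so only a modest rise is expected, a 1.5-fold higher number from compound 3 to compound 4 (0.18 log units; within the scatter). Compound 4 is therefore estimated at 15000 nM, within 7000 nM to 40000 nM.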

Compound 4, solubility: 10000 nM
For compound 4 the middle estimate is 1.5-fold (0.18 log units) above the measured one, and the stated range covers the measured number.
By their numbers in this assay, from the lowest: compounds 2, 3 and 4 (each within the scatter of the next); then compound 1.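

In this assay, a second exchange of the group on the amide-type nitrogen in a ring, now to 5-fluoro-2-methoxyphenyl, gives no change at the digits printed from compound 3 to compound 4 (within the scatter), and methoxy in place of hydrogen on an aromatic carbon gives no change at the digits printed from compound 2 to compound 4 (within the scatter). The difference from compound 1 is now tied to the chain: phenyl in place of 1H-pyrazol-1-yl gives a 5.0-fold lower number from compound 1 to compound 4 (0.70 log units; beyond the scatter). Nothing available explains these results. Open, on these data alone, is how an amine or a carboxylic acid in place of that phenyl would read in this assay, and whether the 1H-pyrazol-1-yl difference holds with other groups on the ring nitrogen.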